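The source may hold more compounds than are shown below. What is called first, only, known or untested is meant among the compounds shown, and "the series" means these compounds.

The account concerns a series sharing one core, set apart by the group on a six-membered aromatic ring of carbon only. Compound 1 is `CCOC(=O)c1c(-c2cccc(-c3ccccc3)c2)[nH]c2cc(OC)ccc2c1=O`, compound 2 is `CCCOc1cccc(-c2[nH]c3cc(OC)ccc3c(=O)c2C(=O)OCC)c1` and compound 3 is `CCOC(=O)c1c(-c2cccc(C(F)(F)F)c2)[nH]c2cc(OC)ccc2c1=O`. In an ADME assay on HepG2 cells (Homo sapiens) for cytotoxicity, read by luminescence, with a stated time of 72 h (a higher number here means that more compound is needed for the effect, a lower number that less compound is needed), compound 1 gives only a limit, > 21500 nM. In this assay compound 2 likewise gives only a limit, > 21500 nM. In this assay compound 3 also gives only a limit, > 21500 nM. Compound 2 therefore stands at the same limit as every other value shown, as the limit of > 21500 nM in this assay, at which 3 of the 3 values shown sit, records. The measured steps bearing on the change are a step that the two limits leave unreadable from compound 1 to compound 2, a step that the two limits leave unreadable from compound 1 to compound 3 and a step that the two limits leave unreadable from compound 2 to compound 3; none of them has a readable size, since each sits between two limits.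

Compound 4 is `CCOC(=O)c1c(-c2cccc(S(C)(=O)=O)c2)[nH]c2cc(OC)ccc2c1=O`. It differs from compound 2 as follows: methylsulfonyl in place of propoxy on an aromatic carbon. Given that every measured exchange at this aromatic carbon left the value at the limit, no step beyond the scatter is expected in this assay in either direction. Compound 4 is accordingly estimated at 21500 nM, within a range from 10000 nM to 60000 nM. The step this estimate means, a number no higher from compound 2 to compound 4 (the limit leaves the size open), is expected to be flat, with a strong chance that only a limit is again reported.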

Compound 4, half-maximal effective concentration: > 21500 nM
Compound 4: a limit, no number; the forecaster's own chance of this, stated with the estimate: 85%; the middle value lies on the limit itself.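

In this assay compound 4 gives only a limit, > 21500 nM. Within the data shown here, no step from compound 1, compound 2 or compound 3 to compound 4 can be read; both ends of each are limits. The compounds shown leave open whether exchanging these groups on the aromatic carbon changes the value at all, with every compound at one point: the limit of > 21500 nM in this assay, at which 4 of the 4 values shown sit.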